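Working notes: tert-butyl to trifluoromethyl in the urea series

A few compounds are considered here, and "the series" means these few. Any claim that something is new, unique, unknown or untested is made for them only; others in the source may bear on it.

In an ADME assay on HepG2 cells (Homo sapiens) for cytotoxicity, with a stated time of 72 h (a higher number here means that more compound is needed for the effect, a lower number that less compound is needed), compound 1 `Cc1cc(NC(=O)Nc2ccc(C(C)(C)C)cc2)c2ccccc2n1` gives 17000 nM, the only numerical half-maximal effective concentration among the three measured compounds. Compound 2 `Cc1cc(NC(=O)Nc2ccc(C)c(Cl)c2)c2ccccc2n1` returns only a limit of the assay, > 25000 nM. Compound 3 `Cc1cc(NC(=O)Nc2ccccc2C(C)(C)C)c2ccccc2n1` also returns only a limit of the assay, > 25000 nM. Going by the values given here, these three compounds differ in more than one place, so the series offers no measured single-change step to serve as a guide.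

The next compound to be tested is compound 4 `Cc1cc(NC(=O)Nc2ccc(C(F)(F)F)cc2)c2ccccc2n1`. It carries trifluoromethyl in place of tert-butyl on an aromatic carbon, para to a large group (trifluoromethyl in place of tert-butyl on an aromatic carbon). The shared core and the urea link stay unchanged.

Among the compounds with values here, with no measured step available, the expectation starts from compound 1 at 17000 nM and assumes no shift beyond the usual scatter in this assay, in either direction. The expected change is small, a 1.1-fold higher number from compound 1 to compound 4 (0.02 log units; within the scatter). Compound 4 may also return only a limit, as the series already shows (the limit of > 25000 nM in this assay, at which 2 of the 3 values shown sit). For compound 4 the estimated value is 18000 nM, with an expected range of 9000 nM to 32000 nM.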

Compound 4, half-maximal effective concentration: 23000 nM
Compound 4: middle estimate off by 1.3-fold (0.11 log units), on the low side; measured number inside the range.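

In this assay the series now has its first readable single-change step: trifluoromethyl in place of tert-butyl on an aromatic carbon, para to a large group, gives a 1.4-fold higher number from compound 1 to compound 4 (0.13 log units; within the scatter). At this position, then, the exchange of one group for the other stays within the scatter, even though the two groups differ in their atoms, carbon on one side and mostly fluorine on the other, and neither side carries a hydrogen-bond donor or acceptor. Compound 4 also returns a number and not a limit, so this position now has two readable values, yet the readable window in this assay stays narrow: the limit of > 25000 nM in this assay, at which 2 of the 4 values shown sit.

From the compounds shown here alone, whether an amine, a carboxylic acid or a longer chain on the same aromatic carbon would move the number beyond the scatter remains open, since the two groups compared here are alike in their counts. Also open is how much of the reading comes from the shared core and the urea link, which stay the same in every compound shown.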